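Replacing phenylsulfanyl with methylamino on the shared core

The source may hold more compounds than are shown below. What is called first, only, known or untested is meant among the compounds shown, and "the series" means these compounds.

In a functional assay on Fem-X cells (Homo sapiens) for cytotoxicity (on this read-out lower numbers stand for stronger inhibition and higher numbers for weaker inhibition), compound 1 `COC1=CC(=O)C=C(C[C@]2(C)[C@@H](C)CC[C@]3(C)C(C)=CCC[C@@H]23)C1=O` gives 9800 nM, while compound 2 `CC1=CCC[C@H]2[C@](C)(CC3=CC(=O)C=C(Sc4ccccc4)C3=O)[C@@H](C)CC[C@]12C` gives 41500 nM, the higher of the two numbers. Compound 3 `CNC1=CC(=O)C=C(C[C@]2(C)[C@@H](C)CC[C@]3(C)C(C)=CCC[C@@H]23)C1=O` has not yet been measured. It departs from compound 2 on a double-bonded ring carbon of the shared core, with methylamino in place of phenylsulfanyl on a double-bonded ring carbon. Going by the values given here, only one measured step bears on this change. Phenylsulfanyl in place of methoxy on that ring carbon gave a 4.2-fold higher number from compound 1 to compound 2 (0.63 log units; beyond the scatter), a modest step. Among the compounds with values here, compound 3 lacks the phenylsulfanyl group, so a step of similar modest size towards a lower number is expected, although no measured step involves methylamino itself. The estimate amounts to an expected 4.6-fold lower number from compound 2 to compound 3 (0.66 log units; beyond the scatter). For compound 3 the estimated value in this assay is 9000 nM, within an expected range of 3000 nM to 27000 nM.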

Compound 3, half-maximal inhibitory concentration: 5200 nM
Beside the measured number, compound 3's estimate is 1.7-fold (0.24 log units) above it, and the stated range covers the measured number.
By their numbers in this assay, from the lowest: compounds 3 and 1 (each within the scatter of the next); then compound 2.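

In this assay, methylamino in place of phenylsulfanyl on the double-bonded ring carbon gives an 8.0-fold lower number from compound 2 to compound 3 (0.90 log units; beyond the scatter) and so adds a second step beyond the scatter at this position, both steps involving phenylsulfanyl. Methylamino in place of methoxy gives a 1.9-fold lower number from compound 1 to compound 3 (0.28 log units; within the scatter) and so does not separate these two groups, which leaves compound 2 alone at the higher number among the three compounds. No measurement shown accounts for this difference.

The compounds leave open whether the higher number of compound 2 goes with the sulfur or with the aromatic ring, a question that methylsulfanyl and phenoxy at this carbon would address. They also leave open how a longer chain on the nitrogen, such as ethylamino or butylamino, would read in this assay.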